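Vero Cell Cytotoxicity: From Bromothiophene to Hydroxymethoxyphenyl

The source may report more compounds than this note shows. Statements on the series, on what has been measured and on what is new or still open speak of the compounds shown alone.

Compound 1 `CN(C)C(=O)C[C@H](CSc1ccccc1)Nc1c(C(=O)N/N=C/c2ccc(OC(F)(F)F)cc2)cnc2ccc(F)cc12`: in an ADME assay on Vero cells (Chlorocebus sabaeus) for cytotoxicity, read by MTT assay, with a stated time of 72 h (a lower number here means a stronger inhibitor, a higher number a weaker inhibitor), compound 1 gives > 62.5 ug/mL, a limit of the assay.
Compound 2 `CN(C)C(=O)C[C@H](CSc1ccccc1)Nc1c(C(=O)N/N=C/c2cccnc2)cnc2ccc(F)cc12`: in this assay compound 2 gives > 62.5 ug/mL, also a limit.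
Compound 3 `CN(C)C(=O)C[C@H](CSc1ccccc1)Nc1c(C(=O)N/N=C/c2ccc(Br)s2)cnc2ccc(F)cc12`: in this assay compound 3 has "not determined" (no result reported).

Compound 3 therefore has no place on the numbers shown. The values of compounds 1 and 2 both sit at the limit of > 62.5 ug/mL in this assay, at which 2 of the 3 values shown sit. Compound 4 `COc1ccc(/C=N/NC(=O)c2cnc3ccc(F)cc3c2N[C@@H](CSc2ccccc2)CC(=O)N(C)C)cc1O` differs from compound 3 by 3-hydroxy-4-methoxyphenyl in place of 5-bromothiophen-2-yl on a carbon with a double bond to nitrogen. Among the compounds with values here, the only measured step, a step that the two limits leave unreadable from compound 1 to compound 2, also swaps the group on the carbon with a double bond to nitrogen, yet both of its ends are limits and its size cannot be read. Within the data shown here, no measured step bears on the change to compound 4 with a readable size, so no direction beyond the scatter is expected. Compound 4 is expected to give 80 ug/mL, in the range 40 ug/mL to 200 ug/mL, most likely reported again only as a limit.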

Compound 4, half-maximal inhibitory concentration: > 62.5 ug/mL
Compound 4: no number, only a limit; the forecaster's own chance of this, stated with the estimate: 75%; the middle value lies beyond the limit too.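

Compound 1, compound 2 and compound 4 each give only a limit of the assay, so the steps among them cannot be read. In this assay the compounds shown leave open whether the group on the carbon with a double bond to nitrogen changes cytotoxicity at all, and where compound 3 stands.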